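Diethylamino for dimethylamino on the tail of compound 1

This account rests on a few compounds, and the source may have more. Where it says the series, first, only, none or still open, it means among the compounds named here.

Measured compounds:
compound 1, `CN(C)CCNc1nc(NCc2ccco2)c2ccccc2n1`: 20%
compound 2, `Fc1ccc2nc(NCCCCN3CCN(c4cccc(Cl)c4Cl)CC3)nc(NCc3ccco3)c2c1`: 95.5%
compound 3, `Clc1cccc(N2CCN(CCCNc3nc(NCc4ccco4)c4ccccc4n3)CC2)c1Cl`: 93.2%

In a functional assay on DU-145 cells (Homo sapiens) for cytotoxicity, read by MTT assay, with a stated time of 2 days, tested at 10 uM (on this read-out higher numbers stand for more inhibition at the one concentration tested (going by the name of the read-out) and lower numbers for less inhibition), compound 1 gives 20%, compound 2 gives 95.5% and compound 3 gives 93.2%. Compound 1 stands lowest of the three numbers. The nearer of the other two values is that of compound 3 and the further that of compound 2; both gaps lie well beyond the scatter. Among the compounds with values here, compounds 2 and 3 each differ from compound 1 in more than one place, so no single-point step between measured compounds is available, and the series gives no measured precedent for a change at the amine tail alone.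

Compound 4, `CCN(CC)CCNc1nc(NCc2ccco2)c2ccccc2n1`, keeps the core of compound 1 and differs from it in one place: diethylamino in place of dimethylamino on a saturated chain carbon, two bonds along the chain from a nitrogen on an aromatic ring. The two amines carry the same count of donors and acceptors and the same absence of charge, and the change adds only two carbons on the tail. Within the data shown here, with no measured step of this kind to lean on, the step of a number 7 percentage points higher from compound 1 to compound 4 (within the scatter) is expected to be small, most likely within the scatter, with at most a modest drift upward. Compound 4 is therefore expected to give about 27% in this assay, in a range from 10% to 50%.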

Compound 4, a percentage reported as inhibition, at one concentration (the size of the read-out at that concentration, not a potency): 28.5%
Compound 4: the middle estimate sits 1.5 percentage points below what was measured; the measured number falls inside the stated range.
By their numbers in this assay, from the lowest: compounds 1 and 4 (each within the scatter of the next); then compounds 3 and 2 (each within the scatter of the next).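

In this assay, the series now has its first step in a single place: diethylamino in place of dimethylamino on a saturated chain carbon, two bonds along the chain from a nitrogen on an aromatic ring, gives a number 8.5 percentage points higher from compound 1 to compound 4 (within the scatter). At this position, then, the added carbon atoms on the terminal amine do not separate the two compounds on this read-out, and compound 4 stays with compound 1 as a single low-lying pair; this rests on one pair and one concentration, so it describes this change alone and sets no trend for the tail. Nothing measured here accounts for the outcome at the level of mechanism or property.

Still open, on these data alone, is how a cyclic amine such as piperidine or morpholine would read in place of diethylamino on the same 2-aminoethyl chain, and whether a longer chain, such as a propyl or butyl linker carrying diethylamino, would read differently from the ethyl chain of compound 4. Equally open, as far as these compounds go, is whether a fluorine on the shared core would alter the reading of compound 4, with the diethylamino tail left as it stands.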